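Aryl amide variation on the benzylsulfonamide series

This account rests on a few compounds, and the source may have more. Where it says the series, first, only, none or still open, it means among the compounds named here.

Compound 1 `COc1ccccc1C(=O)NCc1ccc(CNS(=O)(=O)c2ccccc2)cc1`: 1 nM
Compound 2 `O=C(NCc1ccc(CNS(=O)(=O)c2ccccc2)cc1)c1c(Cl)cc(Cl)cc1Cl`: 10 nM

Among the measured compounds shown here, in an assay on MDA-MB-231 cells for binding affinity to C-X-C chemokine receptor type 4 (Homo sapiens), read by immunofluorescence and microscopy, with stated times of 10 min and 30 min (a higher number here means that more compound is needed for the effect, a lower number that less compound is needed), compound 2 stands highest of the two numbers measured; the only neighbour lies at a 10-fold higher number from compound 1 to compound 2 (1.00 log units; beyond the scatter). Compound 3 `O=C(NCc1ccc(CNS(=O)(=O)c2ccccc2)cc1)c1cccc(Cl)c1` is not yet measured. Its change from compound 2: 3-chlorophenyl in place of 2,4,6-trichlorophenyl on a carbonyl carbon. For the measured compounds named here, the one step bearing on the aryl group on the carbonyl carbon is a 10-fold higher number from compound 1 to compound 2 (1.00 log units; beyond the scatter), a modest change, and no measured step removes chlorine atoms, so the direction is uncertain. The expected step is a 2.0-fold lower number from compound 2 to compound 3 (0.30 log units; within the scatter), not clearly beyond the scatter. Compound 3 is expected to give 5 nM (range 1 nM to 30 nM).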

Compound 3, effective concentration (reported as EC, without a stated level of effect): 1000 nM
Beside the measured number, compound 3's estimate is 200-fold (2.30 log units) below it; measured number above the stated range.
By their numbers in this assay, from the lowest: compound 1; then compound 2; then compound 3.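

In this assay the aryl group on the carbonyl carbon proves far more sensitive than the first pair showed: 3-chlorophenyl in place of 2,4,6-trichlorophenyl gives a 100-fold higher number from compound 2 to compound 3 (2.00 log units; beyond the scatter), and 3-chlorophenyl in place of 2-methoxyphenyl gives a 1000-fold higher number from compound 1 to compound 3 (3.00 log units; beyond the scatter). Fewer chlorine atoms therefore do not preserve the number here, and the loss exceeds a 10-fold higher number from compound 1 to compound 2 (1.00 log units; beyond the scatter). No supporting data bear on this result.

Still open, on these data alone, is whether the number depends on the count of chlorine atoms or on where they sit. An amine or a carboxylic acid on this aryl ring also remains untested in the compounds shown.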